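Chain Lengthening Toward a Fourth Analogue

The source may hold more compounds than are shown below. What is called first, only, known or untested is meant among the compounds shown, and "the series" means these compounds.

Compound 1 `CCC(CC)(c1ccc(OCC(=O)C(C)(C)Cc2ccccc2)c(C)c1)c1ccc(OC[C@@H](O)CO)c(C)c1` and compound 2 `CCC(CC)(c1ccc(OCC(=O)C(C)(C)CCc2ccccc2)c(C)c1)c1ccc(OC[C@@H](O)CO)c(C)c1` share one core and differ by benzyl in place of phenyl on a saturated chain carbon, two bonds along the chain from a carbonyl carbon. In an assay on HL-60 cells for activation of vitamin D3 receptor (Homo sapiens) (on this read-out higher numbers stand for an effect only at larger amounts of compound and lower numbers for an effect already at smaller amounts), compound 1 gives 21000 nM, and compound 2 gives 23000 nM; the step is a 1.1-fold higher number from compound 1 to compound 2 (0.04 log units; within the scatter). Compound 3 `CCC(CC)(c1ccc(OCC(O)C(C)(C)CCCc2ccccc2)c(C)c1)c1ccc(OC[C@@H](O)CO)c(C)c1` rests on a different core; the difference between the two cores is not broken down here. In this assay compound 3 gives 3600 nM, the lowest of the three. Compound 4 `CCC(CC)(c1ccc(OCC(O)C(C)(C)CCCCc2ccccc2)c(C)c1)c1ccc(OC[C@@H](O)CO)c(C)c1` is not yet measured and differs from compound 3 by benzyl in place of phenyl on a saturated chain carbon, five bonds along the chain from an oxygen on a saturated carbon. This is the same kind of change as from compound 1 to compound 2, but the place differs: there it lay two bonds along the chain from a carbonyl carbon, here five bonds along the chain from an oxygen on a saturated carbon. Since the earlier step was a 1.1-fold higher number from compound 1 to compound 2 (0.04 log units; within the scatter), the step from compound 3 to compound 4 is expected to be a 1.1-fold higher number from compound 3 to compound 4 (0.05 log units; within the scatter). Compound 4 is therefore estimated at 4000 nM in this assay, between 1500 nM and 12000 nM.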

Compound 4, half-maximal effective concentration: > 30000 nM
Compound 4: a limit, no number; the forecaster's own chance of this, stated with the estimate: 5%; middle value at least 7.5-fold (0.87 log units) away from the limit.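

The same change gives an at least 8.3-fold higher number from compound 3 to compound 4 (0.92 log units; beyond the scatter) in this assay, so its effect did not carry over unchanged from one core to the other: the same change on two cores in this assay, a 1.1-fold higher number (0.04 log units; within the scatter) from compound 1 to compound 2 and an at least 8.3-fold higher number (0.92 log units; beyond the scatter) from compound 3 to compound 4, at least 7.6-fold (0.88 log units) apart, beyond the scatter of two such steps

For compound 4, the reading of > 30000 nM is a limit of the assay and not a number: the limit of > 30000 nM in this assay, at which 1 of the 4 values shown sits.

This shows that the effect of the change depends on where it is made, but it does not show the true size of the step, or whether the difference between the cores or the chain length at the place of the change is responsible.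

Still open, going by these compounds, is how 3-phenylpropyl and 4-phenylbutyl would behave on the core of compound 1. Also open, on these data alone, is what a longer chain, or an amine or a carboxylic acid in place of the phenyl, would do.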